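From carbamoyl to trifluoromethoxy at a limit

The compounds below may be only part of what the source reports. "The series", "measured", "known", "first", "only" and "open" are said of these compounds alone.

In an ADME assay on HEK293 cells (Homo sapiens) for cytotoxicity, with a stated time of 72 h (a higher number here means that more compound is needed for the effect, a lower number that less compound is needed), compound 1 (`Cc1cc(NC(=O)Nc2ccc(F)cc2)c2ccccc2n1`) gives > 25000 nM as a limit of the assay and not as a number. Compound 2 (`Cc1cc(NC(=O)Nc2ccc(N(C)C)cc2)c2ccccc2n1`) gives > 25000 nM as a limit too. Compound 3 (`Cc1cc(NC(=O)Nc2ccc(C(N)=O)cc2)c2ccccc2n1`) likewise gives > 25000 nM as a limit, so it has no exact place in the series.

Compound 4 (`Cc1cc(NC(=O)Nc2ccc(OC(F)(F)F)cc2)c2ccccc2n1`) carries trifluoromethoxy in place of carbamoyl on an aromatic carbon, para to a large group (trifluoromethoxy in place of carbamoyl on an aromatic carbon).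

The measured changes that bear on this swap are a step that the two limits leave unreadable from compound 1 to compound 2 together with a step that the two limits leave unreadable from compound 1 to compound 3 and a step that the two limits leave unreadable from compound 2 to compound 3 in the same setting. None of them has a size that can be carried over. Going by the values given here, their common ground is the limit of > 25000 nM in this assay, at which 3 of the 3 values shown sit, and that is the only guide in this assay here. No step beyond the usual scatter is therefore expected, and the estimated change is a number no higher from compound 3 to compound 4 (the limit leaves the size open) in either direction.

Compound 4 is expected near 25000 nM with an estimated range from 10000 nM to 40000 nM and will most likely be reported as a limit again.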

Compound 4, half-maximal effective concentration: 14000 nM
Compound 4: the middle estimate sits 1.8-fold (0.25 log units) above what was measured; the measured number falls inside the stated range.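

In this assay, going by these compounds alone, compound 4 gives 14000 nM, the first reading at this position that is a number and not a limit. The comparisons give an at least 1.7-fold lower number from compound 3 to compound 4 (0.25 log units; that floor lies within the scatter), an at least 1.7-fold lower number from compound 2 to compound 4 (0.25 log units; that floor lies within the scatter) and an at least 1.7-fold lower number from compound 1 to compound 4 (0.25 log units; that floor lies within the scatter); each is only a floor on the true size and lies within the scatter, so none of them yet establishes a real difference. The steps among compound 1, compound 2 and compound 3 cannot be read, and most of the set stays at the limit: the limit of > 25000 nM in this assay, at which 3 of the 4 values shown sit.

Still open, as far as these compounds go, is how large the gap between compound 4 and the other three compounds really is, since their exact numbers are unknown. Also open, from the compounds shown here alone, is how the number responds to other groups at this position, such as trifluoromethyl, chloro, a carboxylic acid or a longer alkoxy chain.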